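Lengthening the Linker Chain in the Amide Series

The source may hold more compounds than are shown below. What is called first, only, known or untested is meant among the compounds shown, and "the series" means these compounds.

Compound 1 `CN(C)C(=O)c1cc2cnc(Nc3ccc(S(=O)(=O)NCCCCCCN=C=S)cc3)nc2n1C1CCCC1`: 42.4% in a functional assay on NCI-H1299 cells (Homo sapiens) for inhibition, read by CCK-8 assay, with a stated time of 72 h, tested at 1 uM; a higher number here means a stronger effect of the compound at the concentration tested, a lower number a weaker effect
Compound 2 `CN(C)C(=O)c1cc2cnc(Nc3ccc(S(=O)(=O)NCCCCCCCN=C=S)cc3)nc2n1C1CCCC1`: 58.9% in this assay
Compound 3 `CN(C)C(=O)c1cc2cnc(Nc3ccc(C(=O)NCCCN=C=S)cc3)nc2n1C1CCCC1`: 65.1% in this assay

All three compounds share the same core and differ only in the linker that carries the terminal isothiocyanate. Compound 3 gives the highest of the three numbers, but its gap to compound 2 lies within the usual scatter, so the two cannot be ranked against each other; only its gap to compound 1 is clear. Compound 1 and compound 2 differ by one chain carbon, and that step, a number 16.5 percentage points higher from compound 1 to compound 2 (beyond the scatter), went upward.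

Compound 4 `CN(C)C(=O)c1cc2cnc(Nc3ccc(C(=O)NCCCCCCN=C=S)cc3)nc2n1C1CCCC1` has not yet been measured. It differs from compound 3 as follows: a group of 6 heavy atoms (4 carbon, 1 nitrogen, 1 sulfur; no ring) in place of a group of 3 heavy atoms (1 carbon, 1 nitrogen, 1 sulfur; no ring), on a saturated chain carbon, three bonds along the chain from an amide-type nitrogen. For the measured compounds named here, this is again a lengthening of the chain toward the isothiocyanate, so the step from compound 1 to compound 2 is the only measured step that bears on it. On that basis a small upward step, or none beyond the scatter, is expected in this assay. The expected step is a number 4.9 percentage points higher from compound 3 to compound 4 (within the scatter). Compound 4 is therefore estimated at 70%, within a range from 52% to 85%.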

Compound 4, a percentage reported as inhibition, at one concentration (the size of the read-out at that concentration, not a potency): 49.4%
The estimate for compound 4 lay 20.6 percentage points above the measured number; the measured number lies below the stated range.
By their numbers in this assay, from the lowest: compounds 1, 4, 2 and 3 (each within the scatter of the next, the first and the last beyond it).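

Lengthening the chain toward the isothiocyanate in the amide series gives a number 15.7 percentage points lower from compound 3 to compound 4 (beyond the scatter) in this assay, whereas the one earlier lengthening, in the sulfonamide series, gives a number 16.5 percentage points higher from compound 1 to compound 2 (beyond the scatter) and so points the other way. Both steps lie beyond the scatter, so adding chain carbons has no single direction across these four compounds: compound 4 goes against any rule that a longer chain raises the number, and compound 2 goes against any rule that it lowers it. Nothing measured here explains why the two series part ways, and no supporting data on the cause are available.

With only two chain lengths shown in each series, the compounds leave open whether the number in the amide series falls steadily with length, passes through a peak at some intermediate chain, or recovers with a still longer chain such as the heptyl chain of compound 2. They also leave open how much the terminal isothiocyanate itself contributes, which an amine or an acrylamide at the end of the same chain could begin to show.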